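This account rests on a few compounds, and the source may have more. Where it says the series, first, only, none or still open, it means among the compounds named here.

Measured compounds:
- compound 1 `Clc1ccc(CO/N=C/c2c(-c3cccc4ccccc34)nc3sccn23)cc1Cl`: 940 nM
- compound 2 `CC(C)(C)c1ccc(-c2nc3sccn3c2/C=N/OCc2ccc(Cl)c(Cl)c2)cc1`: 2400 nM
- compound 3 `CC1(C)CCC(C)(C)c2cc(-c3nc4sccn4c3/C=N/OCc3ccc(Cl)c(Cl)c3)ccc21`: "not active" (no number reported)

In an assay on HepG2 cells for agonist activity at nuclear receptor subfamily 1 group I member 3 (Homo sapiens), read by a luciferase reporter, with a stated time of 23 h (on this read-out lower numbers stand for an effect already at smaller amounts and higher numbers for an effect only at larger amounts of compound), compound 1 gives 940 nM. Compound 2 stands at the highest of the two numbers shown, with 2400 nM; compound 3 gives no number at all in this assay. For the measured compounds named here, the only single-place step among the measured compounds is a 2.6-fold higher number from compound 1 to compound 2 (0.41 log units; beyond the scatter), a modest step and a different kind of change from the one followed here.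

Compound 4 `Clc1ccc(CO/N=C/c2c(-c3ccccc3)nc3sccn23)cc1Cl` is not yet measured. It differs from compound 2 by hydrogen in place of tert-butyl on an aromatic carbon. Going by the values given here, no measured pair shows this same change, so no step bears on it directly; all that can be said is that compound 3, with the largest group on that position, gave no number in this assay, while compound 1 and compound 2 each gave one. On that basis a step of unknown direction, possibly within the usual scatter, is expected. Compound 4 is estimated at 1500 nM, with a range from 500 nM to 5000 nM, meaning an expected step of a 1.6-fold lower number from compound 2 to compound 4 (0.20 log units; within the scatter).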

Compound 4, half-maximal effective concentration: 580 nM
The estimate for compound 4 lay 2.6-fold (0.41 log units) above the measured number; measured number inside the range.
By their numbers in this assay, from the lowest: compounds 4 and 1 (each within the scatter of the next); then compound 2.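

In this assay, the tert-butyl group on the six-membered aromatic ring can now be judged on its own: replacing it with hydrogen gives a 4.1-fold lower number from compound 2 to compound 4 (0.62 log units; beyond the scatter), so the group is not needed for a number here, and the simple phenyl does better than 4-(tert-butyl)phenyl. The second step, a 1.6-fold lower number from compound 1 to compound 4 (0.21 log units; within the scatter), leaves phenyl and naphthalen-1-yl indistinguishable, so the earlier gap between compound 1 and compound 2 now reads as a penalty tied to 4-(tert-butyl)phenyl rather than as an advantage of naphthalen-1-yl, and compound 3, which gave no number, offers no value to set beside them. No evidence is available that would explain these differences, so the numbers stand only as observations.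

From the compounds shown here alone, it remains open how a methyl, a methoxy group, an amine or a carboxylic acid on that same aromatic carbon would read in this assay, and so whether any group there can bring the number below that of the bare phenyl. The compounds shown also say nothing about changes elsewhere, as all four keep the same core and the same dichlorinated benzyl end.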